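The compounds below may be only part of what the source reports. "The series", "measured", "known", "first", "only" and "open" are said of these compounds alone.

Going by the values given here, compound 3 `CC(C)C(/C=C1/CCNC1=O)c1ccc(-c2ccc3cccc(F)c3c2)[nH]c1=O` gives 8.1 nM in a functional assay on CHO cells for antagonist activity at prostaglandin E2 receptor EP3 subtype (Homo sapiens), read by cAMP accumulation (on this read-out higher numbers stand for weaker inhibition and lower numbers for stronger inhibition), the lowest of the three numbers so far; compound 1 `CC(C)C(Nc1nccs1)c1ccc(-c2ccc3cccc(F)c3c2)[nH]c1=O` gives 10 nM and compound 2 `CC(C)C(Cc1nnn[nH]1)c1ccc(-c2ccc3cccc(F)c3c2)[nH]c1=O` gives 134 nM. The step of a 1.2-fold lower number from compound 1 to compound 3 (0.09 log units; within the scatter) lies within the scatter, whereas a 17-fold lower number from compound 2 to compound 3 (1.22 log units; beyond the scatter) is large. Compound 4 `CC(C)C(Cc1noc(=O)[nH]1)c1ccc(-c2ccc3cccc(F)c3c2)[nH]c1=O` differs from compound 3 by a group of 7 heavy atoms (3 carbon, 2 nitrogen, 2 oxygen; one five-membered aromatic ring with 3 hetero atoms) in place of a group of 7 heavy atoms (5 carbon, 1 nitrogen, 1 oxygen; one five-membered non-aromatic ring with 1 hetero atom), on a saturated chain carbon bound to an aromatic carbon and a saturated chain carbon. Among the compounds with values here, the nearest precedent is a 13-fold higher number from compound 1 to compound 2 (1.13 log units; beyond the scatter), where (1H-tetrazol-5-yl)methyl, likewise a five-membered aromatic ring with hetero atoms on the same saturated chain carbon, carried the weakest number of the set; a 17-fold lower number from compound 2 to compound 3 (1.22 log units; beyond the scatter) points the same way. A step upward beyond the scatter is therefore expected for compound 4, a 9.9-fold higher number from compound 3 to compound 4 (0.99 log units; beyond the scatter). Compound 4 is estimated at 80 nM, within a range of 25 nM to 250 nM.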

Compound 4, half-maximal inhibitory concentration: 70 nM
Compound 4: middle estimate off by 1.1-fold (0.06 log units), on the high side, and the stated range covers the measured number.
By their numbers in this assay, from the lowest: compounds 3 and 1 (each within the scatter of the next); then compounds 4 and 2 (each within the scatter of the next).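

With an 8.6-fold higher number from compound 3 to compound 4 (0.94 log units; beyond the scatter) and a 1.9-fold lower number from compound 2 to compound 4 (0.28 log units; within the scatter), a second five-membered aromatic ring with hetero atoms, held on this saturated chain carbon through a further chain carbon, stays level with the (1H-tetrazol-5-yl)methyl group. Compound 1 goes against any reading that such a ring alone raises the number, as a 7.0-fold higher number from compound 1 to compound 4 (0.85 log units; beyond the scatter) shows for its (1,3-thiazol-2-yl)amino group. No supporting data bear on the reason for these differences. On these data alone, whether a carboxylic acid or a simple amide on this carbon would fall with compounds 1 and 3 or with compounds 2 and 4 stays open.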